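A few compounds are considered here, and "the series" means these few. Any claim that something is new, unique, unknown or untested is made for them only; others in the source may bear on it.

Measured so far in an assay on cells for agonist activity at ecdysone receptor (Bombyx mori), read by a luciferase reporter, with a stated time of 24 h; a lower number here means that less compound is needed, a higher number that more compound is needed for the effect:
- compound 1 `CCCCN(NC(=O)c1ccccc1)C(=O)c1ccccc1` gives 7080 nM
- compound 2 `O=C(NN(C(=O)c1ccccc1)C1CCCCC1)c1ccccc1` gives 891 nM
- compound 3 `O=C(NN(CC1CCCCC1)C(=O)c1ccccc1)c1ccccc1` gives 1700 nM

Among these three, compound 1 stands highest, meaning it needs the most compound for the effect. Its nearest neighbour is compound 3, with a 4.2-fold lower number from compound 1 to compound 3 (0.62 log units; beyond the scatter), and the furthest is compound 2, with a 7.9-fold lower number from compound 1 to compound 2 (0.90 log units; beyond the scatter). Compounds 2 and 3 sit close to each other, with a 1.9-fold higher number from compound 2 to compound 3 (0.28 log units; within the scatter).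

Compound 4 `CCCCN(C(=O)c1ccccc1)N(C(=O)c1ccccc1)C(C)(C)C` is not yet measured. Compared with compound 1, the change is tert-butyl in place of hydrogen on an amide-type nitrogen. This is a different place from the one probed by the measured steps, which all varied the group on the other amide-type nitrogen: both the step to compound 2 and the step to compound 3 replaced a chain there with a ring-bearing group and gave modest improvements. Among the compounds with values here, no measured step touches the position changed here, so the measured steps give only a loose hint that adding a bulkier group on an amide-type nitrogen of this core tends to lower the number modestly. On that basis, compound 4 is expected to show a step of a 3.5-fold lower number from compound 1 to compound 4 (0.55 log units; beyond the scatter) in this assay, with wide uncertainty. The estimate for compound 4 is 2000 nM, with a range from 300 nM to 15000 nM.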

Compound 4, half-maximal effective concentration: > 100000 nM
Compound 4: no number, only a limit; the forecaster's own chance of this, stated with the estimate: 10%; middle value at least 50-fold (1.69 log units) away from the limit.
By their numbers in this assay, from the lowest: compounds 2 and 3 (each within the scatter of the next); then compound 1. At a limit, above all of these: compound 4.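

In this assay, within the data shown here, the first change at this position goes the opposite way to the earlier ones: tert-butyl in place of hydrogen on an amide-type nitrogen gives an at least 14-fold higher number from compound 1 to compound 4 (1.14 log units; beyond the scatter), a large step. Compounds 1, 2 and 3 all keep that hydrogen and differ only in the group on the other amide-type nitrogen, where the steps were modest and downward, with a 7.9-fold lower number from compound 1 to compound 2 (0.90 log units; beyond the scatter) and a 4.2-fold lower number from compound 1 to compound 3 (0.62 log units; beyond the scatter), so they gave no warning that this second nitrogen would tolerate a substituent so poorly. The reading for compound 4 is a limit and not a number: the limit of > 100000 nM in this assay, at which 1 of the 4 values shown sits.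

The compounds shown cannot separate the loss of the hydrogen from the arrival of tert-butyl, since the two happen together in this single change. A methyl or an ethyl group on this nitrogen, or tert-butyl placed on the core of compound 2 instead of compound 1, would be needed to tell whether any group is unwelcome here or only one as large as tert-butyl.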